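A Limit Compound Gains a Chloro Group

The source may report more compounds than this note shows. Statements on the series, on what has been measured and on what is new or still open speak of the compounds shown alone.

Compound 1 `COc1ccc(C(=O)/C=C/c2ccc(N(C)C)cc2)c2c1C=CC(C)(C)O2` gives 730 nM
Compound 2 `COc1ccc(C(=O)/C=C/c2ccc([N+](=O)[O-])cc2)c2c1C=CC(C)(C)O2` gives 2610 nM
Compound 3 `COc1ccc(C(=O)/C=C/c2ccc(O)cc2)c2c1C=CC(C)(C)O2` gives > 10000 nM (a limit, not a number)

These values come from a functional assay on HepG2 cells (Homo sapiens) for antiproliferative activity, read by MTT assay, with a stated time of 24 h; a lower number here means a stronger inhibitor, a higher number a weaker inhibitor. Compound 3 has only a limit and no number: the limit of > 10000 nM in this assay, at which 1 of the 3 values shown sits.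

Compound 4 `COc1ccc(C(=O)/C=C/c2cc(Cl)ccc2O)c2c1C=CC(C)(C)O2` carries 5-chloro-2-hydroxyphenyl in place of 4-hydroxyphenyl on a double-bonded chain carbon bound to a double-bonded chain carbon.

Three measured steps each swap one group on an aromatic carbon. There is a modest 3.6-fold higher number from compound 1 to compound 2 (0.55 log units; beyond the scatter), a large at least 13-fold higher number from compound 1 to compound 3 (1.13 log units; beyond the scatter) and an at least modest an at least 3.8-fold higher number from compound 2 to compound 3 (0.58 log units; beyond the scatter). They show that one such swap can shift the result well beyond the scatter, but none brings in the group that enters here, so they are only a loose guide.

Compound 2 reaches 2610 nM with a single swap, so a modest move to a lower number in this assay is expected. Compound 4 may also stay at the limit. The expected change is an at least 2.5-fold lower number from compound 3 to compound 4 (0.39 log units; beyond the scatter). For compound 4 the estimated value is 4000 nM, with an expected range from 1300 nM to 10000 nM.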

Compound 4, half-maximal inhibitory concentration: 6640 nM
The estimate for compound 4 lay 1.7-fold (0.22 log units) below the measured number; measured number inside the range.
By their numbers in this assay, from the lowest: compound 1; then compound 2; then compound 4. At a limit, above all of these: compound 3.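

Compound 3 gives only a limit and not a number: the limit of > 10000 nM in this assay, at which 1 of the 4 values shown sits.

Placing 5-chloro-2-hydroxyphenyl at this position gives an at least 1.5-fold lower number from compound 3 to compound 4 (0.17 log units; that floor lies within the scatter), so the true size of this change stays unknown, even though compound 4 gives a real number in this assay. Against the two other groups measured here, the new group does less well, with a 2.5-fold higher number from compound 2 to compound 4 (0.41 log units; beyond the scatter) and a 9.1-fold higher number from compound 1 to compound 4 (0.96 log units; beyond the scatter).

Going from 4-hydroxyphenyl to 5-chloro-2-hydroxyphenyl changes two things at once, the place of the hydroxy group and the added chlorine, so the compounds shown cannot tell which of the two matters. Going by these compounds, how a chlorophenyl group without hydroxy, or a phenyl ring bearing a carboxylic acid, would read at this place also stays open.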